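Chloro in place of fluoro: compound 2 to compound 3

The source may report more compounds than this note shows. Statements on the series, on what has been measured and on what is new or still open speak of the compounds shown alone.

Measured in an ADME assay on L02 cells (Homo sapiens) for cytotoxicity, read by MTT assay, with a stated time of 24 h; on this read-out higher numbers stand for weaker inhibition and lower numbers for stronger inhibition:
- compound 1 `CN1C/C(=C\c2cccnc2)C(=O)/C(=C/c2ccccc2F)C1`: 15900 nM
- compound 2 `O=C1/C(=C/c2cccnc2)CN(S(=O)(=O)c2ccc(F)cc2)C/C1=C\c1ccccc1F`: 15600 nM

Only these two compounds have been measured so far, and compound 2 stands level with compound 1 within the scatter. Among the measured compounds shown here, the single measured step is a 1.0-fold lower number from compound 1 to compound 2 (0.01 log units; within the scatter). Even that exchange, from methyl to (4-fluorophenyl)sulfonyl on the ring amine nitrogen, left the value in this assay unmoved.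

Compound 3 `O=C1/C(=C/c2cccnc2)CN(S(=O)(=O)c2ccc(Cl)cc2)C/C1=C\c1ccccc1F` differs from compound 2 by chloro in place of fluoro on an aromatic carbon. This is chloro in place of fluoro on an aromatic carbon, para to a large group, turning 4-fluorophenyl into 4-chlorophenyl. For the measured compounds named here, no fluoro-to-chloro exchange has been measured, so the step from compound 1 is the only guide, and it is a weak one.

No shift beyond the scatter is expected, and the estimated step is a 1.1-fold lower number from compound 2 to compound 3 (0.03 log units; within the scatter). For compound 3 the expected value is 14500 nM, with an estimated range of 7000 nM to 30000 nM.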

Compound 3, half-maximal inhibitory concentration: > 20000 nM
Compound 3 ended at the assay's limit (the forecaster's own chance of this, stated with the estimate: 4%); at least 1.3-fold (0.13 log units) between middle value and limit.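

In this assay, compound 3 gives > 20000 nM, which is a limit of the assay and not a number. Chloro in place of fluoro on the aromatic carbon gives an at least 1.2-fold higher number from compound 2 to compound 3 (0.10 log units; that floor lies within the scatter), and the full exchange on the ring amine nitrogen gives an at least 1.2-fold higher number from compound 1 to compound 3 (0.09 log units; that floor lies within the scatter), so both steps are floors within the scatter and their true sizes cannot be read. Still, the earlier exchange of methyl for (4-fluorophenyl)sulfonyl left the value in place, whereas this one-atom change on the sulfonyl aryl ring is the first to reach the end of the readable range: the limit of > 20000 nM in this assay, at which 1 of the 3 values shown sits.

From the compounds shown here alone, how far the true value of compound 3 lies from that of compound 2 remains open. Also open, going by these compounds, is how bromo, methoxy, nitrile or an amine on the same aromatic carbon would read.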